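A few compounds are considered here, and "the series" means these few. Any claim that something is new, unique, unknown or untested is made for them only; others in the source may bear on it.

Measured compounds:
- compound 1, `C[C@@H]1CCCN1c1c(C#N)c2c(N)nc(Nc3cn[nH]c3)nc2n1C`, 0.4 nM
- compound 2, `Cn1c(NCc2ccccc2F)c(C#N)c2c(N)ncnc21`, 120 nM
- compound 3, `C[C@@H]1CCCN1c1[nH]c2ncnc(N)c2c1C#N`, 14 nM

All three numbers come from an assay on isolated protein for binding affinity to Leucine-rich repeat serine/threonine-protein kinase 2 variant G2019S (Homo sapiens), read by TR-FRET and LanthaScreen, with a stated time of 2 h; a lower number here means a stronger inhibitor, a higher number a weaker inhibitor. Compound 1 has the lowest number of the three, and both gaps that separate it from the others lie beyond the usual scatter: compound 3 stands nearest to it, compound 2 furthest away. Compound 1 is therefore the strongest binder among the measured set.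

The next compound, compound 4, has the structure `Cc1n[nH]cc1Nc1nc(N)c2c(C#N)c(N3CCC[C@H]3C)n(C)c2n1`. It is obtained from compound 1 by a single change, methyl in place of hydrogen on an aromatic carbon. Among the compounds with values here, no pair of measured compounds differs by this change, so no direct precedent for its size exists here.

Given how small the added group is and the lack of any measured step to compare against, compound 4 is expected to remain close to compound 1 in this assay, with a step of a 1.3-fold higher number from compound 1 to compound 4 (0.10 log units; within the scatter) that is estimated to fall within the scatter rather than beyond it, in either direction. The estimated value for compound 4 is 0.5 nM, with a range from 0.15 nM to 1.6 nM.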

Compound 4, inhibition constant: 2 nM
For compound 4 the middle estimate is 4.0-fold (0.60 log units) below the measured one; measured number outside the range, above it.
By their numbers in this assay, from the lowest: compound 1; then compound 4; then compound 3; then compound 2.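

In this assay, within the data shown here, the change from 1H-pyrazol-4-yl to 3-methyl-1H-pyrazol-4-yl gives the first step in this set that alters one place only, a 5.0-fold higher number from compound 1 to compound 4 (0.70 log units; beyond the scatter), a modest step that lies beyond the scatter. Among these compounds, it shows that this aromatic carbon of the five-membered ring, next to the ring nitrogen and next to the ring atom that bears a large group, is sensitive to a single added carbon, which the earlier compounds could not show because none of them differed at this place alone. The change weakens binding without abolishing it, since compound 4 still gives 2 nM in this assay. No measurement available here bears on why the number rises with this methyl.

The compounds shown leave open whether a fluorine, a chlorine, an ethyl or a methoxy group on this same aromatic carbon would give a smaller or a larger step than methyl does. They also leave open whether the methyl step would keep its size on a core other than that of compound 1.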